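Removing the methoxy: solubility of compound 4 expected

The compounds below may be only part of what the source reports. "The series", "measured", "known", "first", "only" and "open" are said of these compounds alone.

Three analogues sharing one core have been measured in a physicochemical assay for solubility, in phosphate buffer, at pH 7.4; on this read-out lower numbers stand for lower solubility and higher numbers for higher solubility. Compound 1 `CCOC(=O)c1c(-c2cccc(Cl)c2)[nH]c2cccc(OC)c2c1=O` reaches a limit of the assay, giving > 100000 nM. Compound 2 `CCOC(=O)c1c(-c2ccccc2C)[nH]c2cccc(OC)c2c1=O` likewise returns a limit, giving > 100000 nM. Compound 3 `CCOC(=O)c1c(-c2cccc(OC)c2)[nH]c2cccc(OC)c2c1=O`, the starting point of the present step, also returns a limit, giving > 100000 nM. All three values thus stand at the limit of > 100000 nM in this assay, at which 3 of the 3 values shown sit, so compound 3 cannot be set apart from its two companions. For the same reason the steps among them stay unreadable: a step that the two limits leave unreadable from compound 1 to compound 2, a step that the two limits leave unreadable from compound 1 to compound 3 and a step that the two limits leave unreadable from compound 2 to compound 3.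

Compound 4 `CCOC(=O)c1c(-c2ccccc2)[nH]c2cccc(OC)c2c1=O` differs from compound 3 by hydrogen in place of methoxy on an aromatic carbon. For the measured compounds named here, no measured step bears on this change with a readable size, so nothing tells how far going from 3-methoxyphenyl to phenyl might move the solubility in this assay. What the three measured compounds do show is that three different groups on that ring all leave the solubility beyond the limit. The step that the limit leaves unreadable from compound 3 to compound 4 is therefore expected to be small. The estimate for compound 4 in this assay is 150000 nM, within a range from 60000 nM to 400000 nM.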

Compound 4, solubility: > 100000 nM
Compound 4: no number, only a limit; the forecaster's own chance of this, stated with the estimate: 80%; the middle value does not contradict the limit.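

In this assay compound 4 gives > 100000 nM, which is a limit of the assay and not a number. No step from compound 4 to compound 1, compound 2 or compound 3 can be read, since all four stand at one limit: the limit of > 100000 nM in this assay, at which 4 of the 4 values shown sit.

The compounds shown leave open how far their solubilities differ, if they differ at all.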